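This account rests on a few compounds, and the source may have more. Where it says the series, first, only, none or still open, it means among the compounds named here.

Working notes on the series. Among the measured compounds shown here, compound 2 `O=C(O)c1ccccc1-c1ccc(CCc2ncc(-c3ccccc3)[nH]2)cc1` gives 4950 nM in an in vitro functional assay on cells for agonist activity at Bombesin receptor subtype-3 (Homo sapiens), read by luminescence and calcium flux (on this read-out higher numbers stand for an effect only at larger amounts of compound and lower numbers for an effect already at smaller amounts), the higher of the two numbers measured so far. For the measured compounds named here, the nearest point is compound 1 `N#Cc1cccc(Cc2cnc(CCc3ccc(-c4ccccc4C(=O)O)cc3)[nH]2)c1`, which in this assay gives 812 nM; the two are separated by a 6.1-fold higher number from compound 1 to compound 2 (0.79 log units; beyond the scatter), the only step measured, and it shows that the group on this aromatic carbon shifts the read-out by more than the scatter.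

Compound 3 `CC(C)(C)c1cnc(CCc2ccc(-c3ccccc3C(=O)O)cc2)[nH]1` is next: tert-butyl in place of phenyl on an aromatic carbon. Going by the values given here, no measured step covers this particular exchange. Among the compounds with values here, the single step that bears on the same position, a 6.1-fold higher number from compound 1 to compound 2 (0.79 log units; beyond the scatter), came from swapping 3-cyanobenzyl for phenyl and was modest in size. It tells that the position is sensitive, not in which direction tert-butyl would move the number. A step of comparable size in either direction is therefore possible, and nothing firmer than a value near that of compound 2, with a wide band, can be drawn. Compound 3 is expected to come out around 3500 nM, within 700 nM to 15000 nM. That corresponds to an expected step of a 1.4-fold lower number from compound 2 to compound 3 (0.15 log units; within the scatter), to be read with that width.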

Compound 3, half-maximal effective concentration: 4330 nM
The estimate for compound 3 lay 1.2-fold (0.09 log units) below the measured number; low and high end bracket the measured number.
By their numbers in this assay, from the lowest: compound 1; then compounds 3 and 2 (each within the scatter of the next).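

In this assay, the exchange of phenyl for tert-butyl gives a 1.1-fold lower number from compound 2 to compound 3 (0.06 log units; within the scatter), so on this aromatic carbon the read-out does not distinguish a six-membered aromatic ring of carbon only from a group with no ring and fewer heavy atoms. The comparison with 3-cyanobenzyl gives a 5.3-fold higher number from compound 1 to compound 3 (0.73 log units; beyond the scatter), which, set beside a 6.1-fold higher number from compound 1 to compound 2 (0.79 log units; beyond the scatter), leaves compound 1 as the only one of the three apart from the others, while compound 2 and compound 3 stay within the scatter of each other; the earlier single step showed that the position responds, and this pair shows that the response is not spread evenly across the groups tried. Nothing on hand bears on why 3-cyanobenzyl stands apart from the other two groups.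

Still open, going by these compounds, is whether the lower number of compound 1 goes with the nitrile or with the benzyl carbon, a question that plain benzyl and 3-cyanophenyl at this place would separate. Also open, on these data alone, is how this position answers to a group carrying an amine or a carboxylic acid, or to a longer chain ending in a nitrile.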